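Methoxy added to the pendant aryl ring of compound 2

The source may hold more compounds than are shown below. What is called first, only, known or untested is meant among the compounds shown, and "the series" means these compounds.

Measured so far in a functional assay on MCF7 cells (Homo sapiens) for antiproliferative activity, with a stated time of 48 h; a higher number here means a weaker inhibitor of growth, a lower number a stronger inhibitor of growth:
compound 1 `Cc1cc(O)c(C2=NN(c3ccc(S(N)(=O)=O)cc3)C(c3ccccc3Cl)C2)cc1Cl`, compound 1 gives 1750 nM
compound 2 `COc1ccc(C2CC(c3cc(Cl)c(C)cc3O)=NN2c2ccc(S(N)(=O)=O)cc2)cc1OC`, compound 2 gives 3070 nM

Going by the values given here, compound 2 holds the highest of the two numbers in this assay, but its only neighbour is compound 1, and that step, a 1.8-fold higher number from compound 1 to compound 2 (0.24 log units; within the scatter), does not separate the two compounds.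

Compound 3 `COc1ccc(C2CC(c3cc(Cl)c(C)cc3O)=NN2c2ccc(S(N)(=O)=O)cc2)c(OC)c1OC` is the next member of the series. It differs from compound 2 by methoxy in place of hydrogen on an aromatic carbon.

Among the compounds with values here, no measured step adds a methoxy to this ring. Within the data shown here, the single measured step, from compound 1 to compound 2, exchanged the whole group on the saturated ring carbon and stayed within the scatter, so the shared core appears to carry the activity with only a modest dependence on that pendant ring. On that basis the change from compound 2 to compound 3 is expected to give no step beyond the scatter in this assay, estimated as a 1.0-fold lower number from compound 2 to compound 3 (0.01 log units; within the scatter).

Compound 3 is therefore estimated at 3000 nM in this assay, with a range from 1200 nM to 8000 nM.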

Compound 3, concentration for 50% growth inhibition: 2770 nM
Compound 3: middle estimate off by 1.1-fold (0.03 log units), on the high side, within the range that was stated.
By their numbers in this assay, from the lowest: compounds 1, 3 and 2 (each within the scatter of the next).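

In this assay, the move from 3,4-dimethoxyphenyl to 2,3,4-trimethoxyphenyl gives a 1.1-fold lower number from compound 2 to compound 3 (0.04 log units; within the scatter), so a methoxy at this position, ortho to a large group and ortho to a methoxy group, produces no readable change in growth inhibition. The larger exchange of 2-chlorophenyl for 2,3,4-trimethoxyphenyl on the saturated ring carbon gives a 1.6-fold higher number from compound 1 to compound 3 (0.20 log units; within the scatter), so all three pendant rings on the shared core now stand within the scatter of one another in this assay, and neither a second nor a third ring substitution pattern separates from the 2-chlorophenyl compound. Nothing available explains this flat response or shows what it reflects in the cells.

On these data alone, whether the flat response holds for a pendant ring carrying an amine or a carboxylic acid, or for a longer chain in place of that ring, remains open. All three compounds also share the same sulfonamide group and the same ring bearing chloro, methyl and hydroxyl groups, so the dependence of this assay on those parts of the shared core cannot be read from these compounds.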